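A few compounds are considered here, and "the series" means these few. Any claim that something is new, unique, unknown or untested is made for them only; others in the source may bear on it.

Compound 1 `O=S(=O)(NCCNc1nccc(-c2c(-c3cccc(F)c3)nc3sccn23)n1)c1ccc(F)cc1`: 9450 nM
Compound 2 `Cc1ccc(S(=O)(=O)NCCNc2nccc(-c3c(-c4cccc(F)c4)nc4sccn34)n2)cc1`: 15400 nM

In a functional assay on A-375 cells (Homo sapiens) for cytotoxicity, read by MTT assay (on this read-out lower numbers stand for stronger inhibition and higher numbers for weaker inhibition), compound 2 gives the higher of the two numbers, but the gap to compound 1, the step of a 1.6-fold higher number from compound 1 to compound 2 (0.21 log units; within the scatter), lies within the scatter and covers methyl in place of fluoro on an aromatic carbon. Compound 3 `O=C(NCCNc1nccc(-c2c(-c3cccc(F)c3)nc3sccn23)n1)c1ccc(C(F)(F)F)cc1` is not yet measured. It differs from compound 2 by (4-(trifluoromethyl)phenyl)carbonyl in place of (4-methylphenyl)sulfonyl on an amine nitrogen. Within the data shown here, no measured step exchanges the group on the amine nitrogen, and the one measured step, a 1.6-fold higher number from compound 1 to compound 2 (0.21 log units; within the scatter), touches a different part of the molecule. The expected step of a 1.4-fold lower number from compound 2 to compound 3 (0.15 log units; within the scatter) is therefore none beyond the scatter. Compound 3 is estimated at 11000 nM, with a range from 3000 nM to 40000 nM.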

Compound 3, half-maximal inhibitory concentration: 8710 nM
Beside the measured number, compound 3's estimate is 1.3-fold (0.10 log units) above it, within the range that was stated.
By their numbers in this assay, from the lowest: compounds 3, 1 and 2 (each within the scatter of the next).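

Among these compounds, this is the first change at the amine nitrogen, and in this assay replacing (4-methylphenyl)sulfonyl with (4-(trifluoromethyl)phenyl)carbonyl gives a 1.8-fold lower number from compound 2 to compound 3 (0.25 log units; within the scatter) and, against the fluoro analogue, a 1.1-fold lower number from compound 1 to compound 3 (0.04 log units; within the scatter), both within the scatter. The sulfonyl link can thus be exchanged for a carbonyl here with no readable shift in this assay, though the link and the ring substituent change together. Nothing measured here explains this result. Still open, going by these compounds, is how each of those two parts acts alone, and whether a free amine or a longer chain on that nitrogen would move the number beyond the scatter.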